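A few compounds are considered here, and "the series" means these few. Any claim that something is new, unique, unknown or untested is made for them only; others in the source may bear on it.

Three compounds share one core, and each carries a different group on a saturated chain carbon near the amide-type nitrogen. Compound 1 `C[C@H](NC(=O)CN(c1nc(Cl)nc2[nH]cnc12)C1CC1)C(=O)OCc1ccccc1` gives 41.2% in a functional assay on the whole organism (Tail, strain ICR) with Mus musculus as the target, in the tail flick test, with a stated time of 30 min, at a dose of 25 umol/kg by the oral route; on this read-out lower numbers stand for a weaker effect and higher numbers for a stronger effect at the one dose given. Compound 2 `CC(C)[C@H](NC(=O)CN(c1nc(Cl)nc2[nH]cnc12)C1CC1)C(=O)OCc1ccccc1` gives 33.4% in this assay, a change recorded as a number 7.8 percentage points lower from compound 1 to compound 2 (within the scatter). Compound 3 `N=C(N)NCCC[C@H](NC(=O)CN(c1nc(Cl)nc2[nH]cnc12)C1CC1)C(=O)OCc1ccccc1` gives 23.2% in this assay, the lowest of the three numbers, and it sits beyond the scatter from both others, with a number 18 percentage points lower from compound 1 to compound 3 (beyond the scatter) and a number 10.2 percentage points lower from compound 2 to compound 3 (beyond the scatter).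

Compound 4 `O=C(CN(c1nc(Cl)nc2[nH]cnc12)C1CC1)N[C@@H](CC(=O)OCc1ccccc1)C(=O)OCc1ccccc1` has not yet been measured. It differs from compound 3 by a group of 10 heavy atoms (8 carbon, 2 oxygen; one six-membered aromatic ring of carbon only) in place of a group of 6 heavy atoms (3 carbon, 3 nitrogen; no ring), on a saturated chain carbon, two bonds along the chain from an amide-type nitrogen and a carbonyl carbon. The step that bears most on this change is a number 18 percentage points lower from compound 1 to compound 3 (beyond the scatter), since the group of 6 heavy atoms that entered there is the one that now leaves, at the same place on the chain. For the measured compounds named here, removing it may recover part of that loss, while the benzyloxycarbonyl group that enters has no counterpart among the measured compounds, so the expected step is uncertain. For compound 4 a modest rise is expected, a number 9.8 percentage points higher from compound 3 to compound 4 (within the scatter), giving an estimated 33% with a range from 18% to 48%.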

Compound 4, a percentage reported as activity, at one dose (the size of the read-out at that dose, not a potency): 34.7%
Estimate against measurement, compound 4: 1.7 percentage points below; the measured number falls inside the stated range.
By their numbers in this assay, from the lowest: compound 3; then compounds 2, 4 and 1 (each within the scatter of the next).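

Replacing the group of 6 heavy atoms with benzyloxycarbonyl, on a saturated chain carbon two bonds along the chain from an amide-type nitrogen and a carbonyl carbon, gives a number 11.5 percentage points higher from compound 3 to compound 4 (beyond the scatter) in this assay, so the low number of compound 3 does not follow from heavy-atom count alone, as the entering group is the larger one. Set against the shorter side chains, a number 1.3 percentage points higher from compound 2 to compound 4 (within the scatter) and a number 6.5 percentage points lower from compound 1 to compound 4 (within the scatter) both stay inside the usual scatter, so a group carrying an aromatic ring is accepted at this place without a clear loss or gain. Nothing measured here explains why these groups give these numbers.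

As far as these compounds go, it remains open how a carboxylic acid in place of benzyloxycarbonyl would compare with compound 4. From the compounds shown here alone, it is also open how a simple amine in place of the group of 6 heavy atoms would compare with compound 3.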